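Swapping cyclohexyl for methyl in an antiproliferative series

A few compounds are considered here, and "the series" means these few. Any claim that something is new, unique, unknown or untested is made for them only; others in the source may bear on it.

Measured in a functional assay on HBL-100 cells (Homo sapiens) for antiproliferative activity, read by sulforhodamine B assay, with a stated time of 48 h; on this read-out higher numbers stand for weaker inhibition of growth and lower numbers for stronger inhibition of growth:
Compound 1 `COC(=O)C#CC(O/C=C/C(=O)OC)C1CCCCC1`: 2500 nM
Compound 2 `Cc1ccc(S(=O)(=O)C#CC(O/C=C/S(=O)(=O)c2ccc(C)cc2)C(C)C)cc1`: 3800 nM

Compound 1, at 2500 nM, stands level with compound 2, at 3800 nM, since the two values lie within the usual scatter of each other. Neither can be ranked above the other. Compound 3 `COC(=O)C#CC(C)O/C=C/C(=O)OC` has not yet been measured. It keeps the core of compound 1 but carries methyl in place of cyclohexyl on a saturated chain carbon bound to an oxygen on an unsaturated carbon and a triple-bonded carbon. Going by the values given here, no measured pair in this small set isolates such a change, so the expectation rests on the structural change alone. At most a slight drift toward weaker inhibition of growth is expected, with no step beyond the scatter in this assay. The estimated move is a 1.6-fold higher number from compound 1 to compound 3 (0.20 log units; within the scatter) in this read-out. Compound 3 is expected at 4000 nM, with an estimated range from 1500 nM to 11000 nM as its likely span.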

Compound 3, concentration for 50% growth inhibition: 300 nM
Compound 3: middle estimate off by 13-fold (1.12 log units), on the high side; measured number outside the range, below it.
By their numbers in this assay, from the lowest: compound 3; then compounds 1 and 2 (each within the scatter of the next).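

In this assay, methyl in place of cyclohexyl on a saturated chain carbon bound to an oxygen on an unsaturated carbon and a triple-bonded carbon gives an 8.3-fold lower number from compound 1 to compound 3 (0.92 log units; beyond the scatter). Compounds 1 and 2 stood level and differ in more than one place, so they could not show that this position responds to the group it carries. Here, the change from six heavy atoms and a ring to one heavy atom and no ring goes with stronger inhibition of growth, but no measurement at hand accounts for this.

The compounds shown leave open how ethyl, a longer chain or an amine at this position would compare with methyl and cyclohexyl. They also leave open whether the same swap would have a similar effect on the core of compound 2.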